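A few compounds are considered here, and "the series" means these few. Any claim that something is new, unique, unknown or untested is made for them only; others in the source may bear on it.

Three compounds have numbers in a functional assay on SW-620 cells (Homo sapiens) for inhibition, read by MTT assay, with a stated time of 48 h; on this read-out lower numbers stand for stronger inhibition of growth and higher numbers for weaker inhibition of growth. Compound 1 `COc1ccccc1-c1cc(-c2ccc(N)cc2)[nH]n1` gives 21100 nM. Compound 2 `COc1ccc(-c2cc(-c3ccccc3)n[nH]2)cc1` gives 27200 nM. Compound 3 `COc1ccc(-c2cc(-c3ccccc3-c3ccccc3)n[nH]2)cc1` gives 890 nM, the lowest of the three, and its gap to compound 1 as well as to compound 2 lies beyond the scatter. The single one-place step among these three is a 31-fold lower number from compound 2 to compound 3 (1.49 log units; beyond the scatter), a phenyl in place of hydrogen on an aromatic carbon.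

Compound 4 `Oc1ccc(-c2cc(-c3ccccc3-c3ccccc3)n[nH]2)cc1` differs from compound 3 in one place only: hydrogen in place of methyl on an oxygen on an aromatic ring. For the measured compounds named here, no measured pair differs in this way. The step of a 31-fold lower number from compound 2 to compound 3 (1.49 log units; beyond the scatter) concerns another part of the molecule and therefore says nothing about what exchanging the methyl on the oxygen for hydrogen will do. Going by the values given here, with no comparable step to draw on, the change is expected to shift this assay little, if at all, beyond the scatter, so the estimated step is a 1.3-fold higher number from compound 3 to compound 4 (0.13 log units; within the scatter). Compound 4 is thus expected to give about 1200 nM, with a range from 300 nM to 5000 nM.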

Compound 4, concentration for 50% growth inhibition: 25900 nM
Beside the measured number, compound 4's estimate is 22-fold (1.33 log units) below it; measured number above the stated range.
By their numbers in this assay, from the lowest: compound 3; then compounds 1, 4 and 2 (each within the scatter of the next).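

In this assay, the methyl on the oxygen of the 4-methoxyphenyl group proves to be far from a neutral detail: methoxy to hydroxy gives a 29-fold higher number from compound 3 to compound 4 (1.46 log units; beyond the scatter). The low number of compound 3 therefore rests on two features, since the added phenyl in a 31-fold lower number from compound 2 to compound 3 (1.49 log units; beyond the scatter) does not keep that number once the methyl is gone. No available evidence bears on what lies behind this step.

The compounds shown leave open whether a longer chain on the oxygen, such as ethyl, or an amine or a fluorine in place of the methoxy would keep the low number of compound 3. They also leave open whether hydrogen in place of methyl on the oxygen would have any comparable effect in compound 2, which lacks the added phenyl.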